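Regioisomeric dimethoxyphenyl analogues on a shared indole core

The source may report more compounds than this note shows. Statements on the series, on what has been measured and on what is new or still open speak of the compounds shown alone.

Compound 1 `COc1cc(/C(=C\c2cn(C(C)=O)c3ccc(OCc4ccccc4)cc23)C(=O)O)cc(OC)c1OC`: 950 nM
Compound 2 `COc1ccc(OC)c(/C(=C\c2cn(C(C)=O)c3ccc(OCc4ccccc4)cc23)C(=O)O)c1`: 830 nM
Compound 3 `COc1ccc(/C(=C\c2cn(C(C)=O)c3ccc(OCc4ccccc4)cc23)C(=O)O)cc1OC`: 1050 nM

Three measured compounds share one core and differ only in the aryl group on the double-bonded chain carbon bound to a carbonyl carbon and a double-bonded chain carbon. In a functional assay on DU-145 cells (Homo sapiens) for cytotoxicity, read by MTT assay, with a stated time of 72 h (on this read-out higher numbers stand for weaker inhibition and lower numbers for stronger inhibition), compound 1 gives 950 nM, compound 2 gives 830 nM and compound 3 gives 1050 nM. The steps among them are all small: a 1.1-fold lower number from compound 1 to compound 2 (0.06 log units; within the scatter), a 1.1-fold higher number from compound 1 to compound 3 (0.04 log units; within the scatter) and a 1.3-fold higher number from compound 2 to compound 3 (0.10 log units; within the scatter). Compound 3 therefore stands among values that the scatter of this assay does not separate.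

Compound 4 `COc1cc(OC)cc(/C(=C\c2cn(C(C)=O)c3ccc(OCc4ccccc4)cc23)C(=O)O)c1` is the next member of the series. Its change from compound 3 is 3,5-dimethoxyphenyl in place of 3,4-dimethoxyphenyl on a double-bonded chain carbon bound to a carbonyl carbon and a double-bonded chain carbon, so the two have the same atoms, joined differently. The measured steps that bear on it are the rearrangement of two methoxy groups seen in a 1.3-fold higher number from compound 2 to compound 3 (0.10 log units; within the scatter) and the loss of one methoxy group in a 1.1-fold higher number from compound 1 to compound 3 (0.04 log units; within the scatter), both within the scatter. Among the measured compounds shown here, no step among the measured compounds has moved the number beyond the scatter, and the present change is of the same kind. Compound 4 is therefore expected to give a value close to compound 3, with a step of a 1.1-fold lower number from compound 3 to compound 4 (0.02 log units; within the scatter), and an estimated 1000 nM with a range from 500 nM to 2100 nM.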

Compound 4, half-maximal inhibitory concentration: 880 nM
Compound 4: the middle estimate sits 1.1-fold (0.06 log units) above what was measured; the range from low to high includes it.
By their numbers in this assay, from the lowest: compounds 2, 4, 1 and 3 (each within the scatter of the next).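

The 3,5-dimethoxyphenyl group adds a third arrangement of two methoxy groups on the double-bonded chain carbon, and in this assay the rearrangements that lead to it give a 1.2-fold lower number from compound 3 to compound 4 (0.08 log units; within the scatter) and a 1.1-fold higher number from compound 2 to compound 4 (0.03 log units; within the scatter) as well. Compound 4 also completes a direct comparison with the 3,4,5-trimethoxyphenyl group of compound 1, where hydrogen in place of methoxy gives a 1.1-fold lower number from compound 1 to compound 4 (0.03 log units; within the scatter) and so shows that this particular methoxy group can be exchanged for hydrogen without a step beyond the scatter. All four aryl groups at this place therefore remain unseparated, which extends the flat picture to a further substitution pattern, and no measurement shown offers an explanation for this result.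

What the compounds shown leave open is whether the number stays in this range when the methoxy groups give way to a different substituent, such as an amine, a hydroxyl group or a fluorine atom. They also cannot say how far methoxy groups can be removed, since a phenyl ring carrying a single methoxy group or none lies outside this set.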